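The source may report more compounds than this note shows. Statements on the series, on what has been measured and on what is new or still open speak of the compounds shown alone.

Compound 1 `C#Cc1cccc(Nc2ncnc3cc(OCCOC(=O)c4ccccc4OC(C)=O)c(OCCOC)cc23)c1`: 1800 nM
Compound 2 `C#Cc1cccc(Nc2ncnc3cc(OCCOC(=O)C(C)c4ccc(CC(C)C)cc4)c(OCCOC)cc23)c1`: 2200 nM
Compound 3 `C#Cc1cccc(Nc2ncnc3cc(OCCOC(=O)c4ccc(C(=O)Nc5ccc6c(c5)C(C)(C)CCC6(C)C)cc4)c(OCCOC)cc23)c1`: > 10000 nM (a limit, not a number)

All three were tested in a functional assay on A-431 cells (Homo sapiens) for antiproliferative activity, read by CCK-8 assay, with a stated time of 72 h; a lower number here means a stronger inhibitor, a higher number a weaker inhibitor. Among the compounds with values here, compound 1 shares the only measured range with compound 2, and the single measured step is a 1.2-fold higher number from compound 1 to compound 2 (0.09 log units; within the scatter). Compound 3 gives only a limit.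

Compound 4 `C#Cc1cccc(Nc2ncnc3cc(OCCOC(=O)c4ccccc4OC(C)=O)c(OCCOC(=O)c4ccccc4OC(C)=O)cc23)c1` departs from compound 1 at a different place: (2-acetoxyphenyl)carbonyl in place of methyl on an oxygen on a saturated carbon. In words, this is (2-acetoxyphenyl)carbonyl in place of methyl on an oxygen on a saturated carbon, so the (2-acetoxyphenyl)carbonyl group of compound 1 appears a second time. Within the data shown here, no measured step covers this place, and the step to compound 2 concerns a group on a carbonyl carbon, so it bears only indirectly. Compound 3 stands at the limit of > 10000 nM in this assay, at which 1 of the 3 values shown sits, which makes a move towards higher numbers in this assay the likelier direction. The estimated step is a 2.2-fold higher number from compound 1 to compound 4 (0.35 log units; beyond the scatter). For compound 4 the expected value is 4000 nM. The estimated range for compound 4 runs from 1500 nM to 10000 nM.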

Compound 4, half-maximal inhibitory concentration: > 10000 nM
Compound 4: only a limit was reported (the forecaster's own chance of this, stated with the estimate: 20%); at least 2.5-fold (0.39 log units) between middle value and limit.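

The oxygen bearing the methyl group on a saturated carbon is now shown to be a place where a change registers in this assay: an at least 5.5-fold higher number from compound 1 to compound 4 (0.74 log units; beyond the scatter). Within the data shown here, the only earlier measured step, a 1.2-fold higher number from compound 1 to compound 2 (0.09 log units; within the scatter), lay within the scatter and concerned a group on a carbonyl carbon, so it said nothing about this oxygen. The new step rests on a limit, not a number, and that limit is now shared more widely in the series: the limit of > 10000 nM in this assay, at which 2 of the 4 values shown sit.

Still open, on these data alone, is whether a small group on this oxygen, such as ethyl, acetyl or a short chain ending in an amine, would keep the number close to that of compound 1 at 1800 nM. Also open is which part of the entering (2-acetoxyphenyl)carbonyl group, the carbonyl or the aromatic ring, accounts for the change.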